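The source may report more compounds than this note shows. Statements on the series, on what has been measured and on what is new or still open speak of the compounds shown alone.

Compounds sharing one core are compared in a functional assay on M14 cells (Homo sapiens) for inhibition, read by sulforhodamine B assay, with a stated time of 48 h; a lower number here means that less compound is tolerated, a higher number that more compound is tolerated. Within the data shown here, compound 3 `COc1cc(-c2nn(-c3cccc(NC(=O)Nc4cccc(C(F)(F)F)c4)c3)cc2-c2ccncc2)ccc1Cl` gives 4650 nM, the lower of the two true numbers so far. Compound 2 `COc1cc(-c2nn(-c3cccc(NC(=O)Nc4ccc(Cl)c(Cl)c4)c3)cc2-c2ccncc2)ccc1Cl` gives 41200 nM. Compound 1 `O=C(Nc1cccc(-n2cc(-c3ccncc3)c(-c3ccc(Cl)c(O)c3)n2)c1)Nc1cccc(C(F)(F)F)c1` gives > 32500 nM, which is a limit of the assay and not a number.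

Compound 4 `COc1cc(-c2nn(-c3cccc(NC(=O)Nc4ccc(Cl)c(C(F)(F)F)c4)c3)cc2-c2ccncc2)ccc1Cl` differs from compound 3 by a single change chloro in place of hydrogen on an aromatic carbon, ortho to a trifluoromethyl group and para to a large group. The step of an at least 6.9-fold lower number from compound 1 to compound 3 (0.84 log units; beyond the scatter) concerns methyl on an oxygen, a different change, so it offers little guidance here. The closer guide is the step of an 8.9-fold lower number from compound 2 to compound 3 (0.95 log units; beyond the scatter), where 3-(trifluoromethyl)phenyl replaces 3,4-dichlorophenyl. The 4-chloro-3-(trifluoromethyl)phenyl group of compound 4 shares its chloro with the group in compound 2 and keeps the trifluoromethyl of compound 3. A rise smaller than that step is therefore expected, estimated as a 1.9-fold higher number from compound 3 to compound 4 (0.29 log units; within the scatter). For compound 4 the estimated value is 9000 nM, with an expected range of 2500 nM to 35000 nM.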

Compound 4, concentration lethal to 50% of the cells: 19100 nM
The estimate for compound 4 lay 2.1-fold (0.33 log units) below the measured number; the measured number falls inside the stated range.
By their numbers in this assay, from the lowest: compound 3; then compound 4; then compound 2.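

In this assay, chloro in place of hydrogen at this position, ortho to a trifluoromethyl group and para to a large group, gives a 4.1-fold higher number from compound 3 to compound 4 (0.61 log units; beyond the scatter), so replacing this hydrogen on the ring clearly changes the read-out. The earlier comparison of the 3,4-dichlorophenyl and 3-(trifluoromethyl)phenyl groups changed two places at once, and the new 4-chloro-3-(trifluoromethyl)phenyl group separates them: trifluoromethyl in place of chloro gives a 2.2-fold lower number from compound 2 to compound 4 (0.33 log units; beyond the scatter). Both parts lie beyond the scatter and point the same way, and among these three compounds the lowest number belongs to the one with no chloro on this ring.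

Only hydrogen and chloro are shown at this position, so it remains open how fluoro, methoxy or an amine would read there. Nothing measured here explains why chloro raises the number.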